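Pyrrolidine thioamide analogue: expectation from the urea series

A few compounds are considered here, and "the series" means these few. Any claim that something is new, unique, unknown or untested is made for them only; others in the source may bear on it.

Going by the values given here, compound 1 `Cc1cc(C(=O)N2CCCCc3ccccc32)ccc1CNC(=O)NCC(=O)OC(C)C` is the reference point; in a functional assay on HEK293 cells for agonist activity at Vasopressin V2 receptor (Homo sapiens), read by a luciferase reporter and cAMP accumulation (a lower number here means that less compound is needed, a higher number that more compound is needed for the effect), compound 1 gives 140 nM, the lowest of the two numbers so far. Compound 2 `Cc1cc(C(=O)N2CCCCc3ccccc32)ccc1CNC(=O)N1CCC[C@H]1C(=O)OC(C)C` carries the five-membered non-aromatic ring on the urea carbonyl carbon, and in this assay compound 2 gives 950 nM, which is a 6.8-fold higher number from compound 1 to compound 2 (0.83 log units; beyond the scatter). Compound 3 `Cc1cc(C(=O)N2CCCCc3ccccc32)ccc1CNC(=O)N1CCC[C@H]1C(=S)N(C)C` is not yet measured. Relative to compound 1 the change is a group of 10 heavy atoms (7 carbon, 2 nitrogen, 1 sulfur; one five-membered non-aromatic ring with 1 hetero atom) in place of a group of 8 heavy atoms (5 carbon, 1 nitrogen, 2 oxygen; no ring), on a carbonyl carbon. Among the compounds with values here, the only measured step that bears on it is a 6.8-fold higher number from compound 1 to compound 2 (0.83 log units; beyond the scatter), which covers the entry of the five-membered ring but not the replacement of the isopropoxycarbonyl terminus by the sulfur-bearing one; that second part has no precedent. The ring step is therefore taken as the main guide, with a wide margin for the untested terminus. For compound 3 the expected value in this assay is 1000 nM, within 300 nM to 4000 nM, corresponding to an expected step of a 7.1-fold higher number from compound 1 to compound 3 (0.85 log units; beyond the scatter).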

Compound 3, half-maximal effective concentration: 3.2 nM
The estimate for compound 3 lay 310-fold (2.49 log units) above the measured number, outside the stated range (below it).
By their numbers in this assay, from the lowest: compound 3; then compound 1; then compound 2.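

Within the five-membered ring series, the terminus on the saturated ring carbon proves decisive: in this assay, replacing the isopropoxycarbonyl group with the sulfur-bearing group gives a 300-fold lower number from compound 2 to compound 3 (2.47 log units; beyond the scatter) and reverses the order set by the ring step. The five-membered non-aromatic ring on the carbonyl carbon therefore carries no penalty of its own, since the loss at compound 2 appears only with the isopropoxycarbonyl terminus, while the full change gives a 44-fold lower number from compound 1 to compound 3 (1.64 log units; beyond the scatter) and places compound 3 lowest of the three. No measurement at hand accounts for this gain.

Open, from the compounds shown here alone, is whether the gain rests on the sulfur or on the dimethylamino end, which a dimethylamide with a carbonyl oxygen in place of the sulfur would separate. Also open, going by these compounds, is whether the sulfur-bearing terminus keeps its effect on an open chain without the ring, and how the opposite ring stereocentre would behave.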